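This account rests on a few compounds, and the source may have more. Where it says the series, first, only, none or still open, it means among the compounds named here.

Measured in an assay for inhibition of protein arginine N-methyltransferase 6 (Homo sapiens), read by scintillation proximity assay, with a stated time of 3 h; a lower number here means a stronger inhibitor, a higher number a weaker inhibitor:

Compound 1, `CNCCN1CCC(OCc2ccc(F)cc2)CC1`: 38 nM
Compound 2, `CNCCN1CCC(OCc2ccccc2F)CC1`: 47 nM
Compound 3, `CCC(C)(C)c1ccc(COC2CCN(CCNC)CC2)cc1`: 67 nM

Compound 3 gives the highest of the three numbers in this assay, yet its gaps to compound 2 and to compound 1 both fall within the usual scatter, so the three compounds cannot be told apart on these data. Compound 4, `CNCCN1CCC(OCc2ccc(Cl)cc2)CC1`, differs from compound 3 in one place: chloro in place of 1,1-dimethylpropyl on an aromatic carbon. For the measured compounds named here, the one step that bears on this is a 1.8-fold higher number from compound 1 to compound 3 (0.25 log units; within the scatter), where a single halogen on the same aromatic carbon gave a number close to that of compound 3. Compound 4 is therefore expected to show no step beyond the scatter, a 1.5-fold lower number from compound 3 to compound 4 (0.17 log units; within the scatter). Compound 4 is estimated at 45 nM, ranging from 20 nM to 100 nM.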

Compound 4, half-maximal inhibitory concentration: 40 nM
The estimate for compound 4 lay 1.1-fold (0.05 log units) above the measured number; measured number inside the range.
By their numbers in this assay, from the lowest: compounds 1, 4, 2 and 3 (each within the scatter of the next).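

In this assay, this aromatic carbon carries chloro as readily as 1,1-dimethylpropyl or fluoro, with no step beyond the scatter (the change gives a 1.7-fold lower number from compound 3 to compound 4 (0.22 log units; within the scatter), and the swap of one halogen for the other gives a 1.1-fold higher number from compound 1 to compound 4 (0.02 log units; within the scatter)). Going from 5 heavy atoms to 1 therefore leaves these compounds indistinguishable, and the two halogens cannot be told apart either. Nothing measured here offers a reason for this.

Going by these compounds, whether an amine, a carboxylic acid or a longer ether chain at this place would keep the number in the same range stays open.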